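A Lactam-Bearing Piperazine Replaces the Methylpiperidine

This account rests on a few compounds, and the source may have more. Where it says the series, first, only, none or still open, it means among the compounds named here.

Among the three compounds measured in an assay on HEK293 cells for inhibition of acid ceramidase (Homo sapiens), read by fluorescence, with stated times of 10 min and 3 h (on this read-out lower numbers stand for stronger inhibition and higher numbers for weaker inhibition), compound 3 `CN1CCC(c2ccc3c(c2)oc(=O)n3C(=O)NCCCCc2ccccc2)CC1` gives 129 nM, the highest of the three numbers, although its gap to compound 2 lies within the scatter. Compound 1 `CCN1CCN(c2ccc3c(c2)oc(=O)n3C(=O)NCCCCc2ccccc2)CC1` gives 56 nM, and compound 2 `CC(C)CN1CCC(c2ccc3c(c2)oc(=O)n3C(=O)NCCCCc2ccccc2)CC1` gives 120 nM. The two measured steps that reach beyond the scatter both start from compound 1: a 2.3-fold higher number from compound 1 to compound 3 (0.36 log units; beyond the scatter), and likewise a 2.1-fold higher number from compound 1 to compound 2 (0.33 log units; beyond the scatter). By contrast, a 1.1-fold higher number from compound 2 to compound 3 (0.03 log units; within the scatter).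

Compound 4 `CN1CCN(c2ccc3c(c2)oc(=O)n3C(=O)NCCCCc2ccccc2)C(=O)C1` differs from compound 3 in one place: 4-methyl-2-oxopiperazin-1-yl in place of 1-methylpiperidin-4-yl on an aromatic carbon. Among the measured compounds shown here, no measured step covers this exact change. The step from compound 1 to compound 3, which sets a nitrogen-linked 4-ethylpiperazin-1-yl against 1-methylpiperidin-4-yl, bears on it only loosely: the entering 4-methyl-2-oxopiperazin-1-yl carries a carbonyl absent from every measured ring. The pair of compounds 2 and 3 shows that altering the substituent on the ring nitrogen alone left the number within the scatter. The expectation for compound 4 is therefore a step of a 1.2-fold higher number from compound 3 to compound 4 (0.07 log units; within the scatter), not clearly beyond the scatter, with wide uncertainty. The estimated value of compound 4 in this assay is 150 nM, expected to fall between 50 nM and 450 nM.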

Compound 4, half-maximal inhibitory concentration in the acid ceramidase assay: 52 nM
Compound 4: the middle estimate sits 2.9-fold (0.46 log units) above what was measured, and the stated range covers the measured number.
By their numbers in the acid ceramidase assay, from the lowest: compounds 4 and 1 (each within the scatter of the next); then compounds 2 and 3 (each within the scatter of the next).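

In the acid ceramidase assay, 4-methyl-2-oxopiperazin-1-yl on this aromatic carbon gives a 2.5-fold lower number from compound 3 to compound 4 (0.39 log units; beyond the scatter), and against the larger 1-isobutylpiperidin-4-yl it gives a 2.3-fold lower number from compound 2 to compound 4 (0.36 log units; beyond the scatter), so the entering ring beats both piperidine-bearing compounds by a modest margin. In the same assay, the acid ceramidase assay shows a 1.1-fold lower number from compound 1 to compound 4 (0.03 log units; within the scatter), which places the two compounds level; among these four compounds, both rings joined through nitrogen thus give lower numbers than both rings joined through carbon, with none going against this, and the added carbonyl does not separate compound 4 from compound 1. The change also has a cost that the earlier compounds could not show, since in a physicochemical assay for solubility, read by HPLC, in phosphate buffer, measured as kinetic solubility, with a stated time of 1 h, at pH 7.4, tested at 250 uM (on this read-out higher numbers stand for higher solubility and lower numbers for lower solubility), compound 3 gives 120000 nM and compound 4 gives 20000 nM, so the gain in inhibition comes with a loss of solubility: the measured solubility of compound 3, 120000 nM, and of compound 4, 20000 nM, a 6.0-fold lower number (0.78 log units; beyond the scatter)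

The compounds shown leave open how much of this loss belongs to the carbonyl and how much to the ring's attachment through nitrogen. A plain 4-methylpiperazin-1-yl group on the same aromatic carbon would separate the two in both read-outs.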